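Inhibition in Rats: Fluoro Swapped for Hydroxy-Methoxyphenyl

The source may report more compounds than this note shows. Statements on the series, on what has been measured and on what is new or still open speak of the compounds shown alone.

Measured compounds:
compound 1, `O=C1/C(=C/c2ccc(Cl)cc2)C=C(c2ccc(Cl)cc2)N1Cc1ccccc1`, 58.7%
compound 2, `O=C1/C(=C/c2ccc(F)cc2)C=C(c2ccc(Cl)cc2)N1Cc1ccccc1`, 58.7%

The two compounds were tested in a functional assay on the whole organism (strain Wistar) for inhibition, with Rattus norvegicus as the target, with stated times of 30 min and 2 h, at a dose of 20 mg/kg by the oral route; a lower number here means less inhibition, a higher number more inhibition at the dose given (going by the name of the read-out). Compound 1 gives 58.7%, and compound 2 gives 58.7%. Going by the values given here, the single step between them, no change at the digits printed from compound 1 to compound 2 (within the scatter), consists of fluoro in place of chloro on an aromatic carbon; it moves the read-out not at all beyond the scatter.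

Compound 3, `COc1cc(/C=C2\C=C(c3ccc(Cl)cc3)N(Cc3ccccc3)C2=O)ccc1O`, has not yet been measured in this assay. It differs from compound 2 by 4-hydroxy-3-methoxyphenyl in place of 4-fluorophenyl on a double-bonded chain carbon bound to a double-bonded ring carbon. Among the compounds with values here, no measured step involves a group like the one that enters, so the step from compound 1 to compound 2 is the only guide, and it bears only loosely: it shows that a change on this aryl ring left the read-out level within the scatter. The expected step of a number 3.7 percentage points lower from compound 2 to compound 3 (within the scatter) is therefore small, with direction uncertain and a wider range than the scatter alone. Compound 3 is estimated at 55%, between 35% and 75%.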

Compound 3, a percentage reported as inhibition, in the whole organism at one dose (the size of the read-out at that dose, not a potency): 36%
Compound 3: the middle estimate sits 19 percentage points above what was measured; low and high end bracket the measured number.
By their numbers in this assay, from the lowest: compound 3; then compounds 1 and 2 (each within the scatter of the next).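

In this assay the position on a double-bonded chain carbon bound to a double-bonded ring carbon proves sensitive to what it carries: 4-hydroxy-3-methoxyphenyl in place of 4-fluorophenyl gives a number 22.7 percentage points lower from compound 2 to compound 3 (beyond the scatter) and in place of 4-chlorophenyl gives a number 22.7 percentage points lower from compound 1 to compound 3 (beyond the scatter) as the step. The level read-out seen on exchanging one halogen for the other therefore does not hold for every aryl group at this position. Nothing available here explains why the inhibition is lower with the entering group.

Compound 3 brings in hydroxy and methoxy together, so the compounds shown cannot tell which of the two goes with the lower read-out, and a phenyl carrying only one of them would separate them. From the compounds shown here alone, how an amine or a carboxylic acid on this aryl ring would read also remains open.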